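Working notes: the step from compound 3 to compound 4

This account rests on a few compounds, and the source may have more. Where it says the series, first, only, none or still open, it means among the compounds named here.

In a toxicity assay on HEK-293T cells (Homo sapiens) for cytotoxicity, read by MTT assay, with a stated time of 72 h (on this read-out lower numbers stand for stronger inhibition and higher numbers for weaker inhibition), compound 1 `CN(C)CCCCCn1c2c(c3ccccc31)C(=O)c1c[n+]([O-])c3ccccc3c1C2=O` gives 70 nM, compound 2 `O=C1c2c[n+]([O-])c3ccccc3c2C(=O)c2c1c1ccccc1n2Cc1cn(C[C@H](O)CO)nn1` gives 8880 nM and compound 3 `CC1(C)OCC(Cn2cc(Cn3c4c(c5ccccc53)C(=O)c3c[n+]([O-])c5ccccc5c3C4=O)nn2)O1` gives 5510 nM. Compound 3 thus lies within the scatter of compound 2 and well above the number of compound 1. Compound 4 `CC1(C)O[C@@H](CO)[C@H](Cn2cc(Cn3c4c(c5ccccc53)C(=O)c3c[n+]([O-])c5ccccc5c3C4=O)nn2)O1` differs from compound 3 as follows: 5-(hydroxymethyl)-2,2-dimethyl-1,3-dioxolan-4-yl in place of 2,2-dimethyl-1,3-dioxolan-4-yl on a saturated chain carbon bound to an aromatic nitrogen. The closest measured change is a 1.6-fold lower number from compound 2 to compound 3 (0.21 log units; within the scatter), made at the same place and within the scatter. The large 130-fold higher number from compound 1 to compound 2 (2.10 log units; beyond the scatter) removes 4-(dimethylamino)butyl, which neither compound 3 nor compound 4 carries, so it bears little here. No step beyond the scatter is therefore expected in this assay. The expected step is a 1.1-fold higher number from compound 3 to compound 4 (0.04 log units; within the scatter). For compound 4 the estimate is 6000 nM, with an expected range of 2500 nM to 14000 nM.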

Compound 4, half-maximal inhibitory concentration: 120 nM
The estimate for compound 4 lay 50-fold (1.70 log units) above the measured number; the whole stated range lies above it.
By their numbers in this assay, from the lowest: compounds 1 and 4 (each within the scatter of the next); then compounds 3 and 2 (each within the scatter of the next).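

In this assay this place, on a saturated chain carbon bound to an aromatic nitrogen, proves sensitive to the dioxolane substituent: adding the hydroxymethyl group of 5-(hydroxymethyl)-2,2-dimethyl-1,3-dioxolan-4-yl gives a 46-fold lower number from compound 3 to compound 4 (1.66 log units; beyond the scatter) and thus a step beyond the scatter, unlike the earlier change here. Hydroxyl groups alone do not account for the drop, as 1,2-dihydroxyethyl in compound 2 also carries them and the change to compound 4 gives a 74-fold lower number from compound 2 to compound 4 (1.87 log units; beyond the scatter) in the same assay.

Open, on these data alone, is whether the hydroxymethyl group or the defined stereocentres carry the step, and whether an amine or a carboxylic acid in its place would hold the number. Nothing on hand accounts for the step.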